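The source may hold more compounds than are shown below. What is called first, only, known or untested is meant among the compounds shown, and "the series" means these compounds.

Compound 3 `COc1ccc(-c2nc(SCC(=O)c3sc(-c4ccccc4)nc3C)[nH]c(=O)c2C#N)cc1OC` gives 80.8% in a functional assay on U-87MG ATCC cells for antiproliferative activity against U-87 MG (Homo sapiens), read by MTT assay, with a stated time of 48 h, tested at 5 uM (on this read-out higher numbers stand for a weaker effect at the one concentration tested and lower numbers for a stronger effect), the lowest of the three numbers shown. Compound 1 `COc1ccc(-c2nc(SCC(=O)c3sc(-c4ccccc4)nc3C)[nH]c(=O)c2C#N)cc1` gives 97.3% in this assay, and the step of a number 16.5 percentage points lower from compound 1 to compound 3 (beyond the scatter) is the only measured one that bears on the present change. Compound 2 `COc1ccc(-c2nc(C)c(C(=O)CSc3nc(-c4ccc(Cl)cc4)c(C#N)c(=O)[nH]3)s2)cc1`, which also carries a 4-chlorophenyl group, gives 102% in this assay. Compound 4 `Cc1nc(-c2ccccc2)sc1C(=O)CSc1nc(-c2ccc(Cl)cc2)c(C#N)c(=O)[nH]1` differs from compound 3 by 4-chlorophenyl in place of 3,4-dimethoxyphenyl on an aromatic carbon. Since the two methoxy groups leave entirely and the step from compound 1 to compound 3 was modest, compound 4 is expected to move back up, by about a number 16.2 percentage points higher from compound 3 to compound 4 (beyond the scatter). Compound 4 is therefore estimated at 97%, within a range of 85% to 108%, in this assay.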

Compound 4, a percentage reported as activity, at one concentration (the size of the read-out at that concentration, not a potency): 90.9%
Estimate against measurement, compound 4: 6.1 percentage points above; the range from low to high includes it.
By their numbers in this assay, from the lowest: compound 3; then compounds 4, 1 and 2 (each within the scatter of the next, the first and the last beyond it).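

In this assay, 4-chlorophenyl in place of 3,4-dimethoxyphenyl gives a number 10.1 percentage points higher from compound 3 to compound 4 (beyond the scatter), while chloro in place of methoxy on that aromatic group gives a number 6.4 percentage points lower from compound 1 to compound 4 (within the scatter), so only the second methoxy of compound 3 separates from the single-substituent groups. Hydrogen in place of methoxy on an aromatic carbon elsewhere gives a number 11.1 percentage points lower from compound 2 to compound 4 (beyond the scatter), so that other end also moves the number. A methoxy group does not act alike in both places: the same change on two cores in this assay, a number 16.5 percentage points lower (beyond the scatter) from compound 1 to compound 3 and a number 11.1 percentage points higher (beyond the scatter) from compound 4 to compound 2, 27.6 percentage points apart, beyond the scatter of two such steps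

The compounds shown leave open how an amine or a hydroxyl group on this aromatic group would read, and, with a single concentration, how strong the effect of these compounds would be at any other concentration.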